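The source may hold more compounds than are shown below. What is called first, only, known or untested is meant among the compounds shown, and "the series" means these compounds.

Within the data shown here, in a physicochemical assay for lipophilicity, read by HPLC, at pH 7.4 (a higher number here means a more lipophilic compound, a lower number a more polar compound), three compounds have numbers so far. Compound 1 `CC(C)Cc1cc2oc(=O)n(CCC(=O)O)c2cc1Cl` gives 3.03 and compound 2 `C[C@@H](Oc1cc2oc(=O)n(CCC(=O)O)c2cc1Cl)c1cccnn1` gives 0.83. Compound 3 `O=C(O)CCn1c(=O)oc2cc(OCc3ccccn3)c(Cl)cc21` gives 1.32, the second highest of the three. Compound 4 `O=C(O)CCn1c(=O)oc2cc(OCC3CC3)c(Cl)cc21` has not yet been measured.

The change to compound 4 is cyclopropyl in place of pyridin-2-yl on a saturated chain carbon bound to an oxygen on an aromatic ring, or (pyridin-2-yl)methoxy to cyclopropylmethoxy.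

Among the measured compounds shown here, two measured steps bear on this change. Putting (pyridin-2-yl)methoxy in place of isobutyl gave a number 1.71 log units lower from compound 1 to compound 3 (beyond the scatter), the larger of the two. A change confined to the group on the oxygen gave a number 0.49 log units higher from compound 2 to compound 3 (beyond the scatter), the smaller one, and both groups in that pair carry a six-membered aromatic ring with hetero atoms. Neither step removes such a ring while keeping the oxygen, so both guide the estimate only indirectly.

Compound 4 shares with compound 1 at 3.03 a group of carbon only, but keeps the oxygen on the aromatic ring. Only part of the larger step is therefore expected to return. The expected step is a number 0.98 log units higher from compound 3 to compound 4 (beyond the scatter), upward and beyond the scatter in this assay. For compound 4 the estimated value is 2.3, with an expected range of 1.9 to 2.7.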

Compound 4, distribution coefficient: 2.09
Compound 4: the middle estimate sits 0.21 log units above what was measured; measured number inside the range.
By their numbers in this assay, from the lowest: compound 2; then compound 3; then compound 4; then compound 1.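

Working notes on this assay: this is the first step that replaces the ring on the saturated chain carbon bound to an oxygen on an aromatic ring while leaving the oxygen in place, and cyclopropyl in place of pyridin-2-yl gives a number 0.77 log units higher from compound 3 to compound 4 (beyond the scatter) in a single change. Measured against the ring with 2 hetero atoms, the same cyclopropylmethoxy position gives a number 1.26 log units higher from compound 2 to compound 4 (beyond the scatter) and so spans more than the earlier step of a number 0.49 log units higher from compound 2 to compound 3 (beyond the scatter) on this oxygen, while the comparison with isobutyl gives a number 0.94 log units lower from compound 1 to compound 4 (beyond the scatter) and shows that a group of carbon only on the oxygen still leaves a clear gap to the isobutyl compound. No measurement in hand accounts for any of these steps.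

The step from pyridin-2-yl to cyclopropyl changes the ring nitrogen, the ring size, aromatic character and the heavy-atom count all at once, so the share of each stays unresolved. A phenyl ring on the same chain carbon would separate the ring nitrogen from the rest, and a saturated amine ring such as piperidinyl would test a nitrogen outside an aromatic ring.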